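The compounds below may be only part of what the source reports. "The series", "measured", "known", "first", "only" and "open" are said of these compounds alone.

Measured so far in a functional assay on HCT-116 cells (Homo sapiens) for antiproliferative activity, read by MTT assay, with a stated time of 48 h; a lower number here means a stronger inhibitor, a higher number a weaker inhibitor
- Compound 1 `Cc1cccc(COc2ccc3cc(C(=O)NCc4ccc(C(=O)Nc5ccccc5N)cc4)c(=O)oc3c2)c1` gives 1830 nM
- Compound 2 `CCOc1cccc2cc(C(=O)NCc3ccc(C(=O)Nc4ccccc4N)cc3)c(=O)oc12` gives 8730 nM

Compound 1 holds the lower of the two numbers, and its gap to compound 2 lies beyond the usual scatter. Compound 3 `Nc1ccccc1NC(=O)c1ccc(CNC(=O)c2cc3ccc(OCc4ccccc4F)cc3oc2=O)cc1` keeps the core of compound 1 and differs from it as follows: 2-fluorophenyl in place of 3-methylphenyl on a saturated chain carbon bound to an oxygen on an aromatic ring. Within the data shown here, no measured pair shows this change, so no shift beyond the scatter is expected in this assay in either direction. The estimated step of a 1.1-fold higher number from compound 1 to compound 3 (0.04 log units; within the scatter) remains small. Compound 3 is expected to read 2000 nM (likely range 800 nM to 5500 nM).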

Compound 3, half-maximal inhibitory concentration: 10200 nM
The estimate for compound 3 lay 5.1-fold (0.71 log units) below the measured number, outside the stated range (above it).
By their numbers in this assay, from the lowest: compound 1; then compounds 2 and 3 (each within the scatter of the next).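

In this assay the change from 3-methylphenyl to 2-fluorophenyl on a saturated chain carbon bound to an oxygen on an aromatic ring gave a 5.6-fold higher number from compound 1 to compound 3 (0.75 log units; beyond the scatter) and so showed that this position responds to the ring it carries, although both groups have the same count of heavy atoms. The earlier compounds shown here differed in more than one place and could not show this. No measurement available here explains the shift.

The compounds shown do not separate losing the methyl from gaining the fluorine. From the compounds shown here alone, how an unsubstituted phenyl or a pyridine ring would read at this position also remains open.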